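The source may report more compounds than this note shows. Statements on the series, on what has been measured and on what is new or still open speak of the compounds shown alone.

Measured so far:
Compound 1 `CCCCOC(=O)c1cccc(-c2cc(C(=O)Nc3ccncc3)ccc2CN)c1`: 0.367 h
Compound 2 `NCc1ccc(C(=O)Nc2ccncc2F)cc1-c1cccc(C(=O)OCC2CC2)c1`: 0.3 h
Compound 3 `CC(N)c1ccc(C(=O)Nc2ccncc2)cc1-c1ccc(F)cc1`: > 2 h (a limit, not a number)

In an ADME assay on a cell-free system (plasma, Homo sapiens) for metabolic stability, read by LC-MS (a lower number here means that the compound disappears faster, a higher number that the compound lasts longer), compound 1 gives 0.367 h and compound 2 gives 0.3 h, two values within the usual scatter of each other. Compound 3 reports > 2 h, which is a limit of the assay. Compound 1 therefore shares its place on the numbers with compound 2.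

The next compound, compound 4 `CCCCCOC(=O)c1cccc(-c2cc(C(=O)Nc3ccncc3)ccc2CN)c1`, is compound 1 with a methyl in place of hydrogen on a saturated chain carbon, four bonds along the chain from an oxygen next to a carbonyl group. Among the compounds with values here, no pair of measured compounds differs in only one place, so the data offer no direct guide to the size of this step. The expected step, a 1.0-fold lower number from compound 1 to compound 4 (0.02 log units; within the scatter), stays within the scatter and has no firm direction. This expectation rests on the single added carbon and on compound 1 at 0.367 h. For compound 4 the estimated half-life is 0.35 h, with an expected range of 0.15 h to 0.8 h.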

Compound 4, half-life: 0.967 h
The estimate for compound 4 lay 2.8-fold (0.44 log units) below the measured number; measured number above the stated range.
By their numbers in this assay, from the lowest: compounds 2 and 1 (each within the scatter of the next); then compound 4. At a limit, above all of these: compound 3.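

In this assay, the far end of this chain proves sensitive to a small change: methyl in place of hydrogen on a saturated chain carbon, four bonds along the chain from an oxygen next to a carbonyl group, gives a 2.6-fold higher number from compound 1 to compound 4 (0.42 log units; beyond the scatter) and so leaves the compound lasting longer. Within the data shown here, this is the first pair that differs in only one place, so it gives the first measured size of a single change, and that size lies beyond the scatter even though only 1 carbon enters, with no ring and no net charge. Nothing measured here gives the reason for this step.

On these data alone, with one step, it stays open whether a longer chain at this place would extend the rise or reverse it. As far as these compounds go, the effect of a hydroxyl group or an amine at the chain end also remains unknown.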